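Compound 4: 2-fluorophenyl in place of 4-methoxyphenyl

A few compounds are considered here, and "the series" means these few. Any claim that something is new, unique, unknown or untested is made for them only; others in the source may bear on it.

Compound 1: `Cc1ccccc1NNC(=O)C1CCCCC1` — 245 nM
Compound 2: `Cc1ccccc1NNC(=O)CC1CCCCC1` — 151 nM
Compound 3: `COc1ccc(C2(C(=O)NNc3cccc4ncccc34)CCCCC2)cc1` — 51.3 nM

All three were tested in an in vitro functional assay on 1321-N1 cells for antagonist activity at P2X purinoceptor 7 (Rattus norvegicus), read by FLIPR and calcium flux; a lower number here means a stronger inhibitor, a higher number a weaker inhibitor. Among them compound 3 gives the lowest number; its nearest neighbour, compound 2, lies beyond the scatter from it, and compound 1, the furthest, lies further still. Compound 4, `O=C(NNc1cccc2ncccc12)C1(c2ccccc2F)CCCCC1`, differs from compound 3 in one place: 2-fluorophenyl in place of 4-methoxyphenyl on a saturated ring carbon. Among the measured compounds shown here, no measured pair shows this change, so there is nothing to lean on beyond the structures themselves. The group that enters carries no hydrogen-bond acceptor where the group that leaves carried one. The step from compound 3 to compound 4 is expected to be small, a 1.3-fold higher number from compound 3 to compound 4 (0.10 log units; within the scatter), and may well stay within the scatter. Compound 4 is therefore estimated at 65 nM, with a range from 20 nM to 200 nM.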

Compound 4, half-maximal inhibitory concentration: 324 nM
Estimate against measurement, compound 4: 5.0-fold (0.70 log units) below, outside the stated range (above it).
By their numbers in this assay, from the lowest: compound 3; then compounds 2, 1 and 4 (each within the scatter of the next, the first and the last beyond it).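

In this assay, the aryl group on the saturated ring carbon proves to matter: 2-fluorophenyl in place of 4-methoxyphenyl gives a 6.3-fold higher number from compound 3 to compound 4 (0.80 log units; beyond the scatter), so this position does not tolerate every substituted phenyl equally. The change alters both the substituent and its place on the phenyl ring, and this single step cannot separate the two. Nothing measured here gives a reason for the step.

Going by these compounds, whether 4-fluorophenyl or 2-methoxyphenyl would hold the number of compound 3 remains open. So does the outcome with unsubstituted phenyl or with an amine on that ring.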